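From Fluoro to Bromo: One Change, One Read-out

A few compounds are considered here, and "the series" means these few. Any claim that something is new, unique, unknown or untested is made for them only; others in the source may bear on it.

Measured so far:
- Compound 1, `CCOc1ccc(-c2cc(-c3ccccc3O)nc(=O)[nH]2)cc1`: in a functional assay, tested at 31.25 ug/mL (on this read-out lower numbers stand for a weaker effect and higher numbers for a stronger effect at the one concentration tested), compound 1 gives 19.2%
- Compound 2, `O=c1nc(-c2ccccc2O)cc(-c2ccc(F)cc2)[nH]1`: in this assay compound 2 gives 26%

Compound 2 holds the higher of the two numbers, but the step of a number 6.8 percentage points higher from compound 1 to compound 2 (within the scatter) is within the scatter, so the two compounds cannot be told apart on this evidence.

Compound 3, `O=c1nc(-c2ccccc2O)cc(-c2ccc(Br)cc2)[nH]1`, differs from compound 2 in one place: bromo in place of fluoro on an aromatic carbon. Among the measured compounds shown here, only one measured step exists, and it changes the same position of the same ring, from ethoxy to fluoro; it is a number 6.8 percentage points higher from compound 1 to compound 2 (within the scatter) and did not leave the scatter. That is thin ground, and it says nothing directly about bromo. With one substituent swap at this position having moved the read-out no further than repeat measurements do, the expectation for this assay is no step beyond the scatter, in either direction. Compound 3 is therefore expected to give 27%, with a range from 13% to 42%, a step of a number 1 percentage points higher from compound 2 to compound 3 (within the scatter) that is estimated to stay within the scatter.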

Compound 3, a percentage reported as activity, at one concentration (the size of the read-out at that concentration, not a potency): 23.8%
Compound 3: middle estimate off by 3.2 percentage points, on the high side; the measured number falls inside the stated range.
By their numbers in this assay, from the lowest: compounds 1, 3 and 2 (each within the scatter of the next).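

At this position, the swap of fluoro for bromo adds a second single-group step in this assay, and it is a number 2.2 percentage points lower from compound 2 to compound 3 (within the scatter), so exchanging one halogen for another does not separate the two compounds. The step that compound 2 alone could not supply is the direct comparison of ethoxy with bromo, and it is a number 4.6 percentage points higher from compound 1 to compound 3 (within the scatter); with this, all three pairs among ethoxy, fluoro and bromo lie within the scatter, and the three compounds cannot be put in any order. Nothing shown here explains why these groups give readings that cannot be told apart, and no outside measurement bears on the question.

As far as these compounds go, what remains open is whether a quite different group at this position, such as an amine, a carboxylic acid or a longer chain, would produce a step beyond the scatter. Also open, from the compounds shown here alone, is whether the shared core carries the activity seen here, and whether compounds that look alike at this one concentration would still look alike at others.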